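The source may hold more compounds than are shown below. What is called first, only, known or untested is meant among the compounds shown, and "the series" means these compounds.

Working notes on the series. The measured compounds are compound 1 `COc1ccc(-n2c(=O)n(Cc3cc4cc(Cl)ccc4n3CCCC#N)c3cnccc32)c(F)c1`, compound 3 `COc1ccc(-n2c(=O)n(Cc3cc4cc(Cl)ccc4n3CCCC#N)c3cnccc32)cc1OC` and compound 2 `O=c1n(Cc2cc3cnccc3n2CCCCO)c2cnccc2n1C1CC1`. In an ADME assay on HeLa cells (Homo sapiens) for cytotoxicity, read by ATP content, with a stated time of 3 days (on this read-out higher numbers stand for lower toxicity in this test and lower numbers for higher toxicity in this test), compound 1 gives > 50000 nM, a limit of the assay. In this assay compound 3 gives > 50000 nM, also a limit. The step that the two limits leave unreadable from compound 1 to compound 3 is therefore not readable. In this assay compound 2 gives > 100000 nM, again a limit. All values shown are limits, two at the limit of > 50000 nM in this assay, at which 2 of the 3 values shown sit, and one at the limit of > 100000 nM in this assay, at which 1 of the 3 values shown sits, so compound 2 cannot be placed relative to the others. Compound 4 `CC(C)CCn1c(Cn2c(=O)n(C3CC3)c3ccncc32)cc2cnccc21` is not yet measured; it differs from compound 2 by isopropyl in place of 2-hydroxyethyl on a saturated chain carbon, two bonds along the chain from an aromatic nitrogen. Going by the values given here, no measured step bears on this change and no value shown is a number, so no step beyond the scatter is expected; the expected step is a number no higher from compound 2 to compound 4 (the limit leaves the size open). Compound 4 is expected to give 100000 nM in this assay, between 30000 nM and 300000 nM, most likely again as a limit.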

Compound 4, half-maximal cytotoxic concentration: > 50000 nM
Compound 4 ended at the assay's limit; the forecaster's own chance of this, stated with the estimate: 80%; the middle value is on the limit's open side.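

The values of compound 2 and compound 4 in this assay are both limits, so no step can be read between them. Still open, on these data alone, is whether isopropyl in place of 2-hydroxyethyl changes this read-out at all.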